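This account rests on a few compounds, and the source may have more. Where it says the series, first, only, none or still open, it means among the compounds named here.

Among the measured compounds shown here, compound 3 `C=C(Br)C(=O)Nc1cccc(/C=C/C(=O)Nc2ccc(F)cc2)c1` gives 6200 nM in a functional assay on Jurkat cells (Homo sapiens) for inhibition, read by MTT assay, with a stated time of 72 h (a lower number here means a stronger inhibitor, a higher number a weaker inhibitor), which places it second highest of the three numbers measured so far. Its nearest neighbour is compound 2 `C=C(Br)C(=O)Nc1cccc(/C=C/C(=O)Nc2ccccc2)c1`, which in this assay gives 5000 nM; the two lie within the scatter of each other. Furthest from it is compound 1 `COc1cccc(/C=C/C(=O)Nc2cc(OC)c(OC)c(OC)c2)c1`, which in this assay gives 12500 nM, a gap that is also within the scatter.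

The next compound, compound 4 `C=C(Br)C(=O)Nc1cccc(/C=C/C(=O)Nc2cccc(F)c2)c1`, keeps every atom of compound 3 and differs only in how the fluorine is placed: 3-fluorophenyl in place of 4-fluorophenyl on an amide-type nitrogen.

For the measured compounds named here, only one measured step touches a fluorine on this ring, a 1.2-fold higher number from compound 2 to compound 3 (0.09 log units; within the scatter), and it stayed within the scatter. No measured pair moves a fluorine from one position of the ring to another, so the data give no reason to expect the new placement to act differently from the old one. On that basis the step from compound 3 to compound 4 is expected to be small, a 1.0-fold lower number from compound 3 to compound 4 (0.01 log units; within the scatter), with no direction beyond the scatter.

The estimate for compound 4 is therefore 6000 nM, expected to fall between 2500 nM and 14000 nM.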

Compound 4, half-maximal inhibitory concentration: 1000 nM
For compound 4 the middle estimate is 6.0-fold (0.78 log units) above the measured one; measured number outside the range, below it.
By their numbers in this assay, from the lowest: compound 4; then compounds 2, 3 and 1 (each within the scatter of the next, the first and the last beyond it).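

In this assay, the place of the fluorine matters where its presence alone had not: with the same atoms joined differently, 3-fluorophenyl in place of 4-fluorophenyl on an amide-type nitrogen gives a 6.2-fold lower number from compound 3 to compound 4 (0.79 log units; beyond the scatter). Among the compounds shown here, measured against the plain phenyl of compound 2, the two fluorinated rings therefore part ways, since the earlier step remains a 1.2-fold higher number from compound 2 to compound 3 (0.09 log units; within the scatter) while the new one is a 5.0-fold lower number from compound 2 to compound 4 (0.70 log units; beyond the scatter), a change beyond the scatter that the earlier compounds gave no sign of. No available measurement bears on why this one placement changes the number while the other does not.

The compounds shown leave open whether the stronger inhibition belongs to fluorine itself or would also appear with another group at the same place, such as 3-chlorophenyl, 3-methylphenyl or 3-methoxyphenyl, and how 2-fluorophenyl would compare with the two placements already in hand. They also leave open whether a second fluorine, as in 3,5-difluorophenyl, would add to the step, and whether the effect of placement would hold if the rest of the shared core were changed.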